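Aryloxy for benzyl on the amine chain of compound 2

The source may hold more compounds than are shown below. What is called first, only, known or untested is meant among the compounds shown, and "the series" means these compounds.

Working notes on the series. Going by the values given here, compound 2 `CC1CC(=O)N(c2ccccc2C(=O)OCC2CCCN(CCCCCc3ccccc3)C2)C1=O` has the highest number of the two measured so far: in an in vitro functional assay on HEK ts201 cells for antagonist activity at Neuronal acetylcholine receptor; alpha4/beta2 (Homo sapiens), read by fluorescence and calcium flux (a lower number here means a stronger inhibitor, a higher number a weaker inhibitor), compound 2 gives 24500 nM. Its nearest neighbour is compound 1 `COc1ccc(OCCCCCN2CCCC(COC(=O)c3ccccc3N3C(=O)CC(C)C3=O)C2)cc1OC`, which in this assay gives 8320 nM; the step of a 2.9-fold higher number from compound 1 to compound 2 (0.47 log units; beyond the scatter) is the only one measured, and it pairs phenyl against 3,4-dimethoxyphenoxy at the end of the chain.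

Compound 3 `CC1CC(=O)N(c2ccccc2C(=O)OCC2CCCN(CCCCOc3ccc(Cl)c(Cl)c3)C2)C1=O` is not yet measured. The change from compound 2 is 3,4-dichlorophenoxy in place of benzyl on a saturated chain carbon, four bonds along the chain from an amine nitrogen in a ring. It again exchanges a carbocyclic end group for a disubstituted phenoxy end group, which makes the measured step the relevant comparison, though here the chain is one bond shorter and the substituents are chlorines rather than methoxy groups, so the comparison is loose. The expectation is therefore a lower number in this assay for compound 3 than for compound 2, of about the size seen in reverse between compound 1 and compound 2, as a 2.7-fold lower number from compound 2 to compound 3 (0.43 log units; beyond the scatter). Compound 3 is estimated at 9000 nM, with a range of 3000 nM to 27000 nM.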

Compound 3, half-maximal inhibitory concentration: 12300 nM
Estimate against measurement, compound 3: 1.4-fold (0.14 log units) below, and the stated range covers the measured number.
By their numbers in this assay, from the lowest: compounds 1, 3 and 2 (each within the scatter of the next, the first and the last beyond it).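

In this assay, the exchange of benzyl for 3,4-dichlorophenoxy, four bonds along the chain from an amine nitrogen in a ring, gives a 2.0-fold lower number from compound 2 to compound 3 (0.30 log units; within the scatter), whereas the earlier comparison of phenyl with 3,4-dimethoxyphenoxy gave a 2.9-fold higher number from compound 1 to compound 2 (0.47 log units; beyond the scatter), beyond the scatter. The other new step, 3,4-dichlorophenoxy in place of (3,4-dimethoxyphenoxy)methyl at the same place, gives a 1.5-fold higher number from compound 1 to compound 3 (0.17 log units; within the scatter), so compound 3 cannot be separated from either of the two compounds that the earlier step had separated. No evidence is at hand that would explain this reading.

Both new steps change the length of the chain together with the end group, so the compounds shown do not separate the contribution of the chain from that of the chlorine or methoxy substituents. Still open, from the compounds shown here alone, are an unsubstituted phenoxy or a 3,4-dimethoxyphenoxy on the chain of compound 3, a 3,4-dichlorophenoxy on the longer chain of compound 1, and an end group carrying an amine or a carboxylic acid.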